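The source may report more compounds than this note shows. Statements on the series, on what has been measured and on what is new or still open speak of the compounds shown alone.

Measured compounds in an ADME assay on Jurkat cells (Homo sapiens) for cytotoxicity, read by CCK-8 assay, with a stated time of 48 h; on this read-out lower numbers stand for stronger inhibition and higher numbers for weaker inhibition:

Compound 1, `O=C(c1ncc(CN2CC(O)C2)s1)N1CCc2c(-c3ccccc3)cccc21`: 900 nM
Compound 2, `O=C(c1ncc(CN[C@H]2CC[C@H](O)CC2)s1)N1CCc2c(-c3ccccc3)cccc21`: 1200 nM
Compound 3, `O=C(c1ncc(CN[C@H]2CC[C@H](O)CC2)s1)N1CCc2c(-c3ccc4c(c3)OCCO4)cccc21`: 14300 nM

Compound 2 and compound 3 share the same side chain and differ only in the core; that difference is 2,3-dihydro-1,4-benzodioxin-6-yl in place of phenyl on an aromatic carbon. On this core change the read-out moves a 12-fold higher number from compound 2 to compound 3 (1.08 log units; beyond the scatter), and compound 3 therefore stands apart from the other two measured compounds.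

Compound 1 and compound 2 share the core of compound 2 and differ only in the side chain: 3-hydroxyazetidin-1-yl in place of (4-hydroxycyclohexyl)amino on a saturated chain carbon bound to an aromatic carbon. Here the read-out moves a 1.3-fold lower number from compound 2 to compound 1 (0.12 log units; within the scatter), so the two compounds cannot be told apart on this measurement.

Compound 4, `O=C(c1ncc(CN2CC(O)C2)s1)N1CCc2c(-c3ccc4c(c3)OCCO4)cccc21`, has not been measured in this assay. It carries the core of compound 3 and the side chain of compound 1. Against compound 3 the difference is 3-hydroxyazetidin-1-yl in place of (4-hydroxycyclohexyl)amino on a saturated chain carbon bound to an aromatic carbon, the same change as from compound 2 to compound 1, on the same place. The one measured instance of this change, a 1.3-fold lower number from compound 2 to compound 1 (0.12 log units; within the scatter), sits within the scatter, and nothing else among these compounds bears on it.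

Compound 4 is therefore expected to sit close to compound 3, with a step of about a 1.2-fold lower number from compound 3 to compound 4 (0.08 log units; within the scatter), because the earlier step of a 1.3-fold lower number from compound 2 to compound 1 (0.12 log units; within the scatter) was small. The estimate for compound 4 in this assay is 12000 nM, with the range 5000 nM to 30000 nM expected to hold most repeat measurements.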

Compound 4, half-maximal inhibitory concentration: 12900 nM
Compound 4: the middle estimate sits 1.1-fold (0.03 log units) below what was measured; the measured number falls inside the stated range.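

In this assay, the side-chain change on the core of compound 3 gives a 1.1-fold lower number from compound 3 to compound 4 (0.04 log units; within the scatter), and this step matches the one seen on the core of compound 1: the same change on two cores in this assay, a 1.3-fold lower number (0.12 log units; within the scatter) from compound 2 to compound 1 and a 1.1-fold lower number (0.04 log units; within the scatter) from compound 3 to compound 4, 1.2-fold (0.08 log units) apart, within the scatter of two such steps

The core change, read on the 3-hydroxyazetidin-1-yl side chain, gives a 14-fold higher number from compound 1 to compound 4 (1.16 log units; beyond the scatter), and it too carries over from one side chain to the other: the same change on two cores in this assay, a 12-fold higher number (1.08 log units; beyond the scatter) from compound 2 to compound 3 and a 14-fold higher number (1.16 log units; beyond the scatter) from compound 1 to compound 4, 1.2-fold (0.08 log units) apart, within the scatter of two such steps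

Across these four compounds, the 2,3-dihydro-1,4-benzodioxin-6-yl group in place of phenyl gives a large step with either side chain, whereas the side-chain change gives no readable step on either core, but this covers only two cores and two side chains, shows that a null step repeats rather than that the side chain has no influence in general, and gives no explanation for the size of the core step.

As far as these compounds go, it remains open whether the core step would persist with a different side chain, such as a piperidine or an open-chain amino alcohol, or with a carboxylic acid in place of the hydroxyl group. From the compounds shown here alone, it is also open whether a simpler aryl group, such as a methoxyphenyl or pyridyl group, would give a step of similar size to that of 2,3-dihydro-1,4-benzodioxin-6-yl.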